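From 2-(dimethylamino)ethyl to 3-(diethylamino)propyl

The compounds below may be only part of what the source reports. "The series", "measured", "known", "first", "only" and "open" are said of these compounds alone.

Of the compounds shown here, two sharing one core have been tested so far. In a functional assay on HepG2 cells (Homo sapiens) for antiproliferative activity, read by MTT assay, with a stated time of 72 h (on this read-out higher numbers stand for weaker inhibition and lower numbers for stronger inhibition), compound 1 `O=C(N/N=C/c1cccc([N+](=O)[O-])c1)Nc1ccc(Oc2ccnc3[nH]ccc23)c(F)c1` gives 5180 nM, and compound 2 `CN(C)CCn1cccc1/C=N/NC(=O)Nc1ccc(Oc2ccnc3[nH]ccc23)c(F)c1` gives 8980 nM. Compound 2 therefore stands level with compound 1, since repeat measurements of this kind scatter by about that much.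

Compound 3 `CCN(CC)CCCn1cccc1/C=N/NC(=O)Nc1ccc(Oc2ccnc3[nH]ccc23)c(F)c1` keeps all of compound 2 except the end of its side chain: (diethylamino)methyl in place of dimethylamino on a saturated chain carbon, two bonds along the chain from an aromatic nitrogen. Seen one bond further out, 2-(dimethylamino)ethyl becomes 3-(diethylamino)propyl.

Going by the values given here, no measured step tests this change directly. The only one that bears on it is the swap of 3-nitrophenyl for 1-(2-(dimethylamino)ethyl)-1H-pyrrol-2-yl, which is a 1.7-fold higher number from compound 1 to compound 2 (0.24 log units; within the scatter). Even that much larger replacement stayed within the scatter, so there is no ground for expecting a real shift in this assay from a smaller edit at the chain end, in either direction. The expected size is a 1.1-fold lower number from compound 2 to compound 3 (0.05 log units; within the scatter), which would also stay within the scatter. Compound 3 is estimated at 8000 nM, with an expected range of 3500 nM to 18000 nM.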

Compound 3, half-maximal inhibitory concentration: 2140 nM
The estimate for compound 3 lay 3.7-fold (0.57 log units) above the measured number; the measured number lies below the stated range.
By their numbers in this assay, from the lowest: compound 3; then compounds 1 and 2 (each within the scatter of the next).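

Extending 2-(dimethylamino)ethyl to 3-(diethylamino)propyl gives a 4.2-fold lower number from compound 2 to compound 3 (0.62 log units; beyond the scatter) in this assay. Going by these compounds alone, this is the first step to go beyond the scatter, so the far end of this side chain is a place where a small edit can produce a real difference in antiproliferative strength. By the counts of the two groups, the edit adds only carbon, with the nitrogen and the hydrogen-bond donor and acceptor counts unchanged, but nothing available explains why the number falls.

This single step lengthens the chain and enlarges the groups on its nitrogen together, so 2-(diethylamino)ethyl and 3-(dimethylamino)propyl side chains would be needed to tell which of the two edits carries the effect. It also leaves open whether the trend continues with a longer chain, such as 4-(diethylamino)butyl, and whether the chain end needs an amine at all, a question that a carboxylic acid or a hydroxyl group in that place would address.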